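Phenyl for trifluoromethyl on a shared quinolinone-type amide series

This account rests on a few compounds, and the source may have more. Where it says the series, first, only, none or still open, it means among the compounds named here.

Measured compounds:
compound 1, `Cc1c(C(=O)Nc2ccc(Oc3ncnc4[nH]cc(-c5ccccc5)c34)c(F)c2)c(=O)c2cc(C(F)(F)F)ccc2n1C`, 150 nM
compound 2, `CCc1ccc2c(c1)c(=O)c(C(=O)Nc1ccc(Oc3ccnc4[nH]cc(-c5ccccc5)c34)c(F)c1)c(C)n2C`, 30 nM
compound 3, `CCc1ccc2c(c1)c(=O)c(C(=O)Nc1ccc(Oc3ccnc(C(N)=O)c3)c(F)c1)c(C)n2C`, 4380 nM

The three compounds were tested in an assay on isolated protein for inhibition of tyrosine-protein kinase receptor UFO (Homo sapiens), read by FRET and Z'-LYTE, with a stated time of 1.5 h; a higher number here means a weaker inhibitor, a lower number a stronger inhibitor. Compound 1 stands second highest of the three numbers: compound 2 gives a number lower by a margin beyond the usual scatter, while compound 3 gives a number far higher, also beyond the scatter. Within the data shown here, no step between two measured compounds that differ in one place is available, so the pairs can only be read as their two values.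

Compound 4, `Cc1c(C(=O)Nc2ccc(Oc3ncnc4[nH]cc(-c5ccccc5)c34)c(F)c2)c(=O)c2cc(-c3ccccc3)ccc2n1C`, differs from compound 1 in one place: phenyl in place of trifluoromethyl on an aromatic carbon. The aromatic carbon that carries the new group belongs to a six-membered aromatic ring of carbon only within the fused two-ring system of the shared core. Among the measured compounds shown here, no measured pair shows this exchange, so its effect in this assay is not known from the data. The step from compound 1 is expected to be small, within or only slightly beyond the scatter, and if anything toward a higher number, as a 1.5-fold higher number from compound 1 to compound 4 (0.17 log units; within the scatter). Compound 4 is therefore estimated at 220 nM, with a range from 60 nM to 800 nM.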

Compound 4, half-maximal inhibitory concentration: > 10000 nM
Compound 4 was reported as a limit; the forecaster's own chance of this, stated with the estimate: 3%; middle value at least 45-fold (1.65 log units) from the limit.
By their numbers in this assay, from the lowest: compound 2; then compound 1; then compound 3. At a limit, above all of these: compound 4.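

In this assay, compound 4 stands at a limit of the assay and not at a number: the limit of > 10000 nM in this assay, at which 1 of the 4 values shown sits. Read against that limit, phenyl in place of trifluoromethyl on this aromatic carbon gives an at least 66-fold higher number from compound 1 to compound 4 (1.82 log units; beyond the scatter). This is the first one-place change shown at this position, and it shows that the group on this carbon can decide whether a number is obtained at all on the core of compound 1.

The compounds shown do not separate the presence of a ring from the larger count of heavy atoms as the source of this step. On these data alone, whether a methyl group, a methoxy group or a chlorine atom on this carbon would stay close to compound 1 also remains open.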